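The compounds below may be only part of what the source reports. "The series", "measured", "known", "first", "only" and "open" are said of these compounds alone.

Measured compounds:
- compound 3 `COc1cc(C(=O)O)ccc1OCCCCOc1ccc(C(=O)CC(C)C)c(O)c1C`: 614 nM
- compound 2 `Cc1c(OCCCCOc2ccc(C(=O)O)cc2)ccc(C(=O)CC2CCCC2)c1O`: > 10000 nM (a limit of the assay, not a number)
- compound 1 `COc1cc(C(=O)O)ccc1OCCCCOc1ccc(C(=O)C(C)C)c(O)c1C`: "not determined" (no result reported)

Among the compounds with values here, in an assay on HEK293 cells for positive allosteric modulation of metabotropic glutamate receptor 3 (Rattus norvegicus), read by thallium flux, with a stated time of 2.5 min (on this read-out higher numbers stand for an effect only at larger amounts of compound and lower numbers for an effect already at smaller amounts), compound 3 gives 614 nM, the only numeric result so far. Within the data shown here, compound 2 is reported in this assay only as a limit, > 10000 nM; that it sits at the limit is the one piece of evidence beyond compound 3 (the limit of > 10000 nM in this assay, at which 1 of the 3 values shown sits). For compound 1 no result in this assay is reported. Among the measured compounds shown here, no pair of measured compounds differs in a single place, so no measured step is available to calibrate the change below.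

Compound 4 `Cc1c(OCCCCOc2ccc(C(=O)O)cc2)ccc(C(=O)CC(C)C)c1O` is the next member. Relative to compound 3 the change is hydrogen in place of methoxy on an aromatic carbon. The carboxy-bearing ring of compound 4 thus matches that of compound 2, while the ketone side chain matches compound 3. For the measured compounds named here, with compound 2 reporting only a limit and compound 3 the sole number, the direction of the step is uncertain; a weakening beyond the scatter is expected, but a result within the scatter of compound 3 cannot be ruled out. Compound 4 is expected to show a 3.3-fold higher number from compound 3 to compound 4 (0.51 log units; beyond the scatter) against compound 3, giving an estimated value of 2000 nM, within a range of 600 nM to 8000 nM, with a fair chance that only a limit is reported.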

Compound 4, half-maximal effective concentration: 2720 nM
Compound 4: the middle estimate sits 1.4-fold (0.13 log units) below what was measured, and the stated range covers the measured number.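

The methoxy on the aromatic carbon meta to a carboxy group now has a measured step in this assay: hydrogen in its place gives a 4.4-fold higher number from compound 3 to compound 4 (0.65 log units; beyond the scatter) and so shows that this position responds to the change. The step is modest, and compound 4 still returns a number rather than a limit, so the series keeps a measurable response in this assay with hydrogen at this carbon. With hydrogen at this carbon, the ketone side chain also has a step, as isopropyl in place of cyclopentyl on the saturated chain carbon bound to the carbonyl carbon gives an at least 3.6-fold lower number from compound 2 to compound 4 (0.56 log units; beyond the scatter) and only a minimum size can be read, since compound 2 is a limit of the assay and not a number: the limit of > 10000 nM in this assay, at which 1 of the 4 values shown sits.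

Going by these compounds, whether the response belongs to methoxy in particular stays open, and an ethoxy or a fluorine on the same aromatic carbon would test this. It is also unknown whether the cyclopentyl side chain would return a number with methoxy on that carbon, or how a shorter or longer chain in the linker would read.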